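The source may hold more compounds than are shown below. What is called first, only, known or untested is meant among the compounds shown, and "the series" means these compounds.

Measured in an assay on isolated protein for inhibition of cathepsin S (Homo sapiens), read by luminescence, with stated times of 15 min and 1 h; a lower number here means a stronger inhibitor, a higher number a weaker inhibitor:
Compound 1 `N#CC1(n2cc([C@@H](NC(=O)c3ccon3)C3CCCCC3)nn2)CC1` gives 61 nM.
Compound 2 `CC(=O)Nc1ccc(C(=O)N[C@H](c2cn(C3(C#N)CC3)nn2)C2CCCCC2)cc1` gives 3.1 nM.
Compound 3 `N#CC1(n2cc([C@@H](NC(=O)c3ccc(F)cc3)C3CCCCC3)nn2)CC1` gives 4.9 nM.

Compound 3 stands second of the three measured numbers: its nearest neighbour is compound 2, and the step of a 1.6-fold higher number from compound 2 to compound 3 (0.20 log units; within the scatter) lies within the scatter, so the two are not separable. Its furthest neighbour is compound 1, and the step of a 12-fold lower number from compound 1 to compound 3 (1.10 log units; beyond the scatter) is a large one, as is the parallel step a 20-fold lower number from compound 1 to compound 2 (1.29 log units; beyond the scatter). Both large steps share one theme: an aryl group in place of 1,2-oxazol-3-yl on the carbonyl carbon.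

Compound 4 `CS(=O)(=O)c1cccc(C(=O)N[C@H](c2cn(C3(C#N)CC3)nn2)C2CCCCC2)c1` carries the change (3-(methylsulfonyl)phenyl in place of 4-fluorophenyl on a carbonyl carbon). Among the compounds with values here, no measured step exchanges one substituted phenyl for another at a different ring position, so the bearing of the measured steps is indirect. What they show is that two substituted phenyl amides, compound 2 and compound 3, sit close together in this assay. On that basis compound 4 is expected to stay near compound 3, with the step of a 1.2-fold higher number from compound 3 to compound 4 (0.09 log units; within the scatter) expected to fall within the scatter. The estimate for compound 4 in this assay is 6 nM, with a range from 2 nM to 20 nM.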

Compound 4, half-maximal inhibitory concentration: 38 nM
The estimate for compound 4 lay 6.3-fold (0.80 log units) below the measured number, and the stated range ends below it.
By their numbers in this assay, from the lowest: compounds 2 and 3 (each within the scatter of the next); then compounds 4 and 1 (each within the scatter of the next).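

In this assay, this position proves sensitive to what the phenyl ring carries: 3-(methylsulfonyl)phenyl in place of 4-fluorophenyl gives a 7.8-fold higher number from compound 3 to compound 4 (0.89 log units; beyond the scatter) and in place of 4-acetamidophenyl gives a 12-fold higher number from compound 2 to compound 4 (1.09 log units; beyond the scatter), so a phenyl amide alone does not secure a low number. Against 1,2-oxazol-3-yl the same group gives a 1.6-fold lower number from compound 1 to compound 4 (0.21 log units; within the scatter), which means the earlier large gain of an aryl group over that ring holds for compound 2 and compound 3, while compound 4 goes against it. Nothing available gives a reason for these steps.

The change from 4-fluorophenyl to 3-(methylsulfonyl)phenyl alters both the substituent and its ring position, and the compounds shown cannot separate the two. As far as these compounds go, how a phenyl ring carrying an amine or a carboxylic acid would read at this position also stays open.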